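This account rests on a few compounds, and the source may have more. Where it says the series, first, only, none or still open, it means among the compounds named here.

Measured so far in an assay for inhibition of Tryptophan 2,3-dioxygenase (Homo sapiens), with stated times of 10 min and 60 min, tested at 10 uM; on this read-out higher numbers stand for a stronger effect at the one concentration tested and lower numbers for a weaker effect:
Compound 1 `Oc1ccc(CNc2cc(C(F)(F)F)cc3[nH]ncc23)cc1` gives 75%.
Compound 2 `NCCn1ncc2c(NCc3ccccc3[N+](=O)[O-])cc(C(F)(F)F)cc21` gives 25%.

Compound 2 stands at the lower of the two numbers: in this assay it sits well below compound 1, and the gap between them lies beyond the usual scatter. Going by the values given here, no step between these two compounds is counted, since they differ in more than one place.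

Compound 3 `O=[N+]([O-])c1ccccc1CNc1cc(C(F)(F)F)cc2[nH]ncc12` has not yet been measured. It differs from compound 2 in one place: hydrogen in place of 2-aminoethyl on an aromatic nitrogen. Compound 3 thus carries the same unsubstituted ring nitrogen that compound 1 shows, while keeping the nitro-bearing side of compound 2.

Among the compounds with values here, the only compound with that free ring nitrogen, compound 1, gives 75%, so an increase over compound 2 is expected, but no single step in the data fixes its size. The estimate for compound 3 is 45%, with a range of 15% to 75%. That estimate means an expected step of a number 20 percentage points higher from compound 2 to compound 3 (beyond the scatter).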

Compound 3, a percentage reported as inhibition, at one concentration (the size of the read-out at that concentration, not a potency): 89%
Compound 3: the middle estimate sits 44 percentage points below what was measured; measured number outside the range, above it.
By their numbers in this assay, from the lowest: compound 2; then compound 1; then compound 3.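

In this assay, hydrogen in place of 2-aminoethyl on the aromatic nitrogen gives a number 64 percentage points higher from compound 2 to compound 3 (beyond the scatter) and is the first change shown at this position alone. With the nitro-bearing side held constant, the large step ties the 2-aminoethyl group on this nitrogen to the much lower read-out and the free ring nitrogen to the much higher one. Compound 1 and compound 2 differ in more than one place, so their gap could not show this.

Nothing in the data shown explains why the step is so large. On these data alone, it also remains open whether a small methyl group, a 2-hydroxyethyl chain or a longer amine chain on this nitrogen would give the same low read-out, and whether the step would recur with the hydroxyl-bearing side of compound 1.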